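Oxime ether series: acetamido for benzoyl on the aromatic ring

The source may report more compounds than this note shows. Statements on the series, on what has been measured and on what is new or still open speak of the compounds shown alone.

Compound 1 `COc1ccc([C@@H]2C/C(=N/OCc3cn(-c4ccc(C(=O)c5ccccc5)cc4)nn3)c3cc(CC=C(C)C)c(OC)cc3O2)cc1` is the reference point here. In a functional assay on A549 cells (Homo sapiens) for inhibition, read by sulforhodamine B assay, with a stated time of 48 h, tested at 50 uM (a lower number here means less inhibition of growth, a higher number more inhibition of growth at the concentration tested), compound 1 gives 34%. Within the data shown here, the only other measured compound is a differently built analogue, compound 2 `COc1cc2c(cc1CC=C(C)C)C(=O)C[C@@H](c1ccc(Oc3cccc([N+](=O)[O-])c3)cc1)O2`, which gives 37% in this assay, and the two numbers lie within the scatter of each other, so compound 1 cannot be ranked against compound 2 despite the marked difference in structure. Compound 3 `COc1ccc([C@@H]2C/C(=N/OCc3cn(-c4ccc(NC(C)=O)cc4)nn3)c3cc(CC=C(C)C)c(OC)cc3O2)cc1` differs from compound 1 at one aromatic carbon of a six-membered aromatic ring of carbon only, para to a large group: acetamido in place of benzoyl on an aromatic carbon. Among the measured compounds shown here, no pair of measured compounds differing in one place is available, so the size of this change has no precedent. The expectation is that a number 1 percentage points lower from compound 1 to compound 3 (within the scatter) stays within the scatter, with no clear direction. Compound 3 is therefore estimated at 33%, in a range from 15% to 52%.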

Compound 3, percent growth inhibition at one concentration: 19%
Compound 3: middle estimate off by 14 percentage points, on the high side, and the stated range covers the measured number.
By their numbers in this assay, from the lowest: compound 3; then compounds 1 and 2 (each within the scatter of the next).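

Among these compounds, the aromatic carbon para to a large group is not indifferent to what it carries: in this assay acetamido in place of benzoyl gives a number 15 percentage points lower from compound 1 to compound 3 (beyond the scatter) and is the first change that can be read as a single step. Benzoyl brings a six-membered aromatic ring of carbon only and more heavy atoms, while acetamido has no ring and adds a hydrogen-bond donor, so these differences travel together in this one step and cannot be separated. No measurement at hand accounts for the lower growth inhibition.

Open, on these data alone, is whether the ring of benzoyl or the amide hydrogen of acetamido is what matters here. A phenyl group or a simple amine at this carbon would separate the two, and a carboxylic acid would test the position further.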